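The source may hold more compounds than are shown below. What is called first, only, known or untested is meant among the compounds shown, and "the series" means these compounds.

Working notes on the series. All numbers come from a functional assay on DU-145 cells (Homo sapiens) for cytotoxicity, read by CCK-8 assay and cell counting, with a stated time of 2 days; on this read-out lower numbers stand for stronger inhibition and higher numbers for weaker inhibition.

compound 1, `Oc1cccc(-c2cc(-c3ccc(Cl)cc3)nc(-c3cccs3)c2)c1`, 11600 nM
compound 2, `Oc1ccc(-c2cc(-c3ccc(Cl)cc3)nc(-c3ccsc3)c2)cc1`, 6940 nM
compound 3, `Oc1cccc(-c2cc(-c3cccs3)nc(-c3ccccc3Cl)c2)c1`, 1700 nM

Compounds 1 and 2 share the same atoms joined differently; how their two cores differ is not broken down here. Their values in this assay lie within the scatter of each other, so nothing is read into their order. Compound 3 gives the lowest number of the three, and its gap to compound 2 is beyond the scatter.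

Among the compounds with values here, the one counted step is 2-chlorophenyl in place of 4-chlorophenyl on an aromatic carbon. In this assay it made a 6.8-fold lower number from compound 1 to compound 3 (0.83 log units; beyond the scatter).

Compound 4, `Oc1ccc(-c2cc(-c3ccsc3)nc(-c3ccccc3Cl)c2)cc1`, is not yet measured. It differs from compound 2 by 2-chlorophenyl in place of 4-chlorophenyl on an aromatic carbon. This is the same kind of change as the step from compound 1 to compound 3, not the same change: around the place, compound 2 carries a 4-hydroxyphenyl group and a thiophen-3-yl group where compound 1 carries a 3-hydroxyphenyl group and a thiophen-2-yl group.

Because the step of a 6.8-fold lower number from compound 1 to compound 3 (0.83 log units; beyond the scatter) lay beyond the scatter, a step of similar direction is expected here, estimated as a 5.8-fold lower number from compound 2 to compound 4 (0.76 log units; beyond the scatter). The surroundings of the place differ, so the estimate is held looser than that single step. Compound 4 is expected to give about 1200 nM in this assay, between 400 nM and 4000 nM.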

Compound 4, half-maximal inhibitory concentration: 3890 nM
Beside the measured number, compound 4's estimate is 3.2-fold (0.51 log units) below it; the range from low to high includes it.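

In this assay, 2-chlorophenyl in place of 4-chlorophenyl gave a 1.8-fold lower number from compound 2 to compound 4 (0.25 log units; within the scatter), a step that on the core of compound 2 cannot be told from the scatter. Set beside the earlier step, the size of the change did not carry over from one core to the other: the same change on two cores in this assay, a 6.8-fold lower number (0.83 log units; beyond the scatter) from compound 1 to compound 3 and a 1.8-fold lower number (0.25 log units; within the scatter) from compound 2 to compound 4, 3.8-fold (0.58 log units) apart, beyond the scatter of two such steps. This shows that the large step on the core of compound 1 cannot be assumed on another core in this series, but it rests on one pair per core and does not show which difference between the cores matters, as the 4-hydroxyphenyl and thiophen-3-yl groups of compound 2 stand together where compound 1 carries the 3-hydroxyphenyl and thiophen-2-yl groups.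

The compounds shown leave open how the change behaves on a core that pairs the 3-hydroxyphenyl group with the thiophen-3-yl group, or the 4-hydroxyphenyl group with the thiophen-2-yl group, the two combinations that would separate these differences. They also leave open whether the step holds on any core where an amine or a carboxylic acid stands in place of the hydroxyl group.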